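The compounds below may be only part of what the source reports. "The series", "measured", "known", "first", "only" and "open" are said of these compounds alone.

Measured compounds:
compound 1 `Nc1nc(N/N=C/c2cccc(OCc3ccccc3)c2)nc2c1ncn2[C@@H]1O[C@H](CO)[C@@H](O)[C@H]1O` — 13 nM
compound 2 `Nc1nc(N/N=C/c2ccc[nH]2)nc2c1ncn2[C@@H]1O[C@H](CO)[C@@H](O)[C@H]1O` — 8 nM
compound 3 `Nc1nc(N/N=C/c2ccc(C(F)(F)F)cc2C(F)(F)F)nc2c1ncn2[C@@H]1O[C@H](CO)[C@@H](O)[C@H]1O` — > 10000 nM

The three measured compounds share the core of compound 1 and differ only in the aryl group attached to the hydrazone. In an assay on CHO-K1 cells for displacement of a labelled ligand from adenosine receptor A1 (Homo sapiens), read by scintillation counting, with a stated time of 60 min (on this read-out higher numbers stand for weaker inhibition and lower numbers for stronger inhibition), compound 1 gives 13 nM, and compound 2 gives 8 nM; these two values lie within the usual scatter of each other. Compound 3 stands apart: its value of > 10000 nM is a limit of the assay and not a number, namely (the limit of > 10000 nM in this assay, at which 1 of the 3 values shown sits). Compound 3 is thus the only one of the three for which no binding could be quantified.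

Compound 4 `Nc1nc(N/N=C/c2ccc(C(F)(F)F)cc2)nc2c1ncn2[C@@H]1O[C@H](CO)[C@@H](O)[C@H]1O` has not yet been measured in this assay. It differs from compound 3 by hydrogen in place of trifluoromethyl on an aromatic carbon. Going by the values given here, no measured pair describes this change directly, so what it does can only be expected from the surrounding data. Since compound 3 sits at a limit while compound 1 and compound 2 bind well, the step is expected to be large and toward stronger inhibition. Compound 4 is therefore estimated to reach 100 nM, within a range of 15 nM to 1500 nM, corresponding to an expected step of an at least 100-fold lower number from compound 3 to compound 4 (2.00 log units; beyond the scatter).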

Compound 4, inhibition constant: 37 nM
Compound 4: middle estimate off by 2.7-fold (0.43 log units), on the high side, within the range that was stated.
By their numbers in this assay, from the lowest: compounds 2 and 1 (each within the scatter of the next); then compound 4. At a limit, above all of these: compound 3.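

In this assay hydrogen in place of trifluoromethyl on an aromatic carbon, ortho to a large group and meta to a trifluoromethyl group, gives an at least 270-fold lower number from compound 3 to compound 4 (2.43 log units; beyond the scatter) and so shows that this single position separates a measurable value from none. Compound 3 stays a limit of the assay and not a number, so this step has a lower bound only: the limit of > 10000 nM in this assay, at which 1 of the 4 values shown sits. The trifluoromethyl group that remains in compound 4 does not by itself remove binding, yet 4-(trifluoromethyl)phenyl in place of 1H-pyrrol-2-yl still gives a 4.6-fold higher number from compound 2 to compound 4 (0.67 log units; beyond the scatter), a modest step beyond the scatter.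

The compounds shown leave open whether the loss seen with compound 3 belongs to trifluoromethyl itself or would also appear with another group on that carbon, such as a fluorine, a methyl, a methoxy or an amine. They also leave open what happens when the remaining trifluoromethyl group is replaced by hydrogen, a nitrile or a carboxylic acid, and so how much of the step from the pyrrole compound rests on that group.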